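Chain-length variation in cyanoguanidine pyridazinone series

The source may report more compounds than this note shows. Statements on the series, on what has been measured and on what is new or still open speak of the compounds shown alone.

Measured in a functional assay on the whole organism with Rattus norvegicus as the target, at a dose of 100 mg/kg; a lower number here means less inhibition, a higher number more inhibition at the dose given (going by the name of the read-out):
- compound 1 `CC/N=C(/NC#N)NCCCn1nc(-c2ccccc2)cc(C)c1=O`: 23.5%
- compound 2 `N#CNC(=N)NCCCCCn1nc(-c2ccccc2)ccc1=O`: 31%
- compound 3 `C/N=C(/NC#N)NCCCCCn1nc(C)ccc1=O`: 14.9%

Compound 2 carries the largest number of the three in this assay, but compound 1 sits within the scatter of it, so no order can be drawn between these two. Compound 3 lies beyond the scatter below compound 2. None of the three pairs differs in a single place, so the separate parts of compound 2 cannot be weighed from these numbers.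

Compound 4 `N#CNC(=N)NCCCCn1nc(-c2ccccc2)ccc1=O` is not yet measured. It differs from compound 2 only by a group of 6 heavy atoms (2 carbon, 4 nitrogen; no ring) in place of a group of 7 heavy atoms (3 carbon, 4 nitrogen; no ring), on a saturated chain carbon, four bonds along the chain from an aromatic nitrogen. Whether the chain joining the cyanoguanidine to the ring nitrogen matters for inhibition in this assay is not shown by any measured pair; compound 1 and compound 3 each differ from compound 2 in more than one place.

With nothing measured on this point, the step of a number 4 percentage points lower from compound 2 to compound 4 (within the scatter) is expected to stay within the usual scatter, with a slight lean downward. Compound 4 is therefore estimated at 27%, within a range from 12% to 42%.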

Compound 4, a percentage reported as inhibition, in the whole organism at one dose (the size of the read-out at that dose, not a potency): 61.2%
The estimate for compound 4 lay 34.2 percentage points below the measured number; measured number above the stated range.
By their numbers in this assay, from the lowest: compounds 3, 1 and 2 (each within the scatter of the next, the first and the last beyond it); then compound 4.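

In this assay, this position now has its first single-place reading: a group of 6 heavy atoms (2 carbon, 4 nitrogen; no ring) in place of a group of 7 heavy atoms (3 carbon, 4 nitrogen; no ring), on a saturated chain carbon, four bonds along the chain from an aromatic nitrogen, gives a number 30.2 percentage points higher from compound 2 to compound 4 (beyond the scatter). The two groups have the same counts of hydrogen-bond donors and acceptors and neither carries a net charge, so within this pair the chain joining the cyanoguanidine to the aromatic nitrogen clearly matters for inhibition at this dose. No measurement in hand bears on what lies behind this step.

On these data alone, one pair gives a direction for these two chains only, so it remains open whether a shorter chain than in compound 4 would raise or lower inhibition, or whether a longer chain than in compound 2 would lower it further. Also open, as far as these compounds go, is whether an amine or a carboxylic acid at the chain end would keep the inhibition, and whether the chain step holds on the cores of compound 1 and compound 3, each of which differs from compound 4 in more than one place.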